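Phenyl for methyl on the ring nitrogen: series notes

A few compounds are considered here, and "the series" means these few. Any claim that something is new, unique, unknown or untested is made for them only; others in the source may bear on it.

Measured so far, in an assay on isolated protein for inhibition of seed linoleate 13S-lipoxygenase-1 (Glycine max), tested at 0.1 mM; on this read-out higher numbers stand for more inhibition at the one concentration tested (going by the name of the read-out) and lower numbers for less inhibition:
Compound 1 `COC(=O)c1c(O)c2ccccc2n(C)c1=O` gives 72.4%.
Compound 2 `COC(=O)c1c(O)c2ccccc2n(-c2ccccc2)c1=O` gives 100%.
Compound 3 `Cn1c(=O)c(C(=O)NCCCCCCNC(=O)CCCCC2CCSS2)c(O)c2ccccc21` gives 79.1%.

Compounds 1 and 2 share a core and differ in one place: phenyl in place of methyl on an aromatic nitrogen. On this change the read-out moved a number 27.6 percentage points higher from compound 1 to compound 2 (beyond the scatter), and compound 2 sits at the top of the range the assay can report.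

Compound 3 carries a different core, with a long amide-linked chain ending in a dithiolane in place of the methoxycarbonyl group; the difference between the two cores is not broken down here. Its number lies within the scatter of compound 1 and beyond the scatter below compound 2.

Compound 4 `O=C(CCCCC1CCSS1)NCCCCCCNC(=O)c1c(O)c2ccccc2n(-c2ccccc2)c1=O` is not yet measured. It is made from compound 3 by phenyl in place of methyl on an aromatic nitrogen. This is the same kind of change as that from compound 1 to compound 2, though the place lines differ: in compound 1 the nitrogen is meta to a methoxycarbonyl group (4 heavy atoms), in compound 3 it is meta to a large group.

Given that compound 3 starts near compound 1 and the earlier step was a number 27.6 percentage points higher from compound 1 to compound 2 (beyond the scatter), compound 4 is expected to rise by about a number 15.9 percentage points higher from compound 3 to compound 4 (beyond the scatter) in this assay, with the top of the reportable range capping the gain. The estimate for compound 4 is 95%, between 82% and 100%.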

Compound 4, a percentage reported as inhibition, at one concentration (the size of the read-out at that concentration, not a potency): 64%
For compound 4 the middle estimate is 31 percentage points above the measured one, outside the stated range (below it).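

Series notes after compound 4: in this assay, phenyl in place of methyl on an aromatic nitrogen gave a number 15.1 percentage points lower from compound 3 to compound 4 (beyond the scatter), so the change does not hold its direction on the second core. Among these compounds, the result from the core of compound 1 therefore does not carry over to the core of compound 3, in either size or direction: the same change on two cores in this assay, a number 27.6 percentage points higher (beyond the scatter) from compound 1 to compound 2 and a number 15.1 percentage points lower (beyond the scatter) from compound 3 to compound 4, 42.7 percentage points apart, beyond the scatter of two such steps This rests on only two matched pairs read at one concentration, with compound 2 at the top of the reportable range, so it shows that the effect of this change depends on the rest of the molecule in these two cases but not which part of that rest is responsible, nor how the pairs would compare as potencies.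

Still open is whether the reversal goes with the dithiolane end, the amide link or the length of the chain, as no pair shown separates these three features. Methyl and phenyl pairs carrying a carboxylic acid or a shorter chain ending in a simple amide in place of the long chain would bear on this, and a benzyl group on the nitrogen would test whether the result is particular to phenyl.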